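The source may report more compounds than this note shows. Statements on the series, on what has been measured and on what is new or still open speak of the compounds shown alone.

Measured so far in a physicochemical assay, with a stated time of 30 min; a higher number here means a weaker inhibitor, a lower number a stronger inhibitor
- compound 1 `CCc1cccc(NC(=O)C2Cc3cc(OC)c(OC)cc3C2=O)c1` gives 64.1 ug/mL
- compound 2 `CCOc1cccc(NC(=O)C2Cc3cc(OC)c(OC)cc3C2=O)c1` gives 44.9 ug/mL
- compound 3 `COc1cc2c(cc1OC)C(=O)C(C(=O)Nc1cccc(Cl)c1)C2` gives 76.3 ug/mL

Compound 3 lies within the scatter of both other compounds, so the three values form a single group. The next structure is compound 4 `COc1cc2c(cc1OC)C(=O)C(C(=O)Nc1ccccc1Br)C2`, with 2-bromophenyl in place of 3-chlorophenyl on an amide-type nitrogen.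

The measured steps bear on this change only indirectly. Each exchanges one group on an aromatic carbon (a 1.4-fold lower number from compound 1 to compound 2 (0.15 log units; within the scatter); a 1.2-fold higher number from compound 1 to compound 3 (0.08 log units; within the scatter); a 1.7-fold higher number from compound 2 to compound 3 (0.23 log units; within the scatter)), and none leaves the scatter. Among the compounds with values here, no measured compound carries a 2-bromophenyl group, so this exchange is untested. On this evidence, no step beyond the scatter is expected in this assay, and no direction can be assigned with any confidence. The working figure is an expected 1.2-fold lower number from compound 3 to compound 4 (0.09 log units; within the scatter) and should be read as no real change. Compound 4 is expected at 62 ug/mL (estimated range 30 ug/mL to 125 ug/mL).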

Compound 4, half-maximal inhibitory concentration: 65.4 ug/mL
For compound 4 the middle estimate is 1.1-fold (0.02 log units) below the measured one, within the range that was stated.
By their numbers in this assay, from the lowest: compounds 2, 1, 4 and 3 (each within the scatter of the next).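

In this assay, 2-bromophenyl in place of 3-chlorophenyl on the amide-type nitrogen gives a step within the scatter (a 1.2-fold lower number from compound 3 to compound 4 (0.07 log units; within the scatter)). The comparison with 3-ethylphenyl reads the same (a 1.0-fold higher number from compound 1 to compound 4 (0.01 log units; within the scatter)), so this position has now tolerated a change of both the substituent and its printed ring position without any step leaving the scatter. No measurement available here explains this flat response.

The halogen and its ring position changed together in compound 4, so their separate contributions remain unresolved, and 2-chlorophenyl or 3-bromophenyl would separate them. Going by these compounds, it also remains open whether a carboxylic acid or a dimethylamino group on the phenyl ring, or a pyridine ring in place of the phenyl ring, would produce a step beyond the scatter.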